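Swapping the dimethylamino group of compound 3

The source may hold more compounds than are shown below. What is called first, only, known or untested is meant among the compounds shown, and "the series" means these compounds.

Values in a functional assay on HUVEC cells (Homo sapiens), read by scintillation counting and thymidine incorporation, with a stated time of 24 h; on this read-out lower numbers stand for stronger inhibition and higher numbers for weaker inhibition:
Compound 1 `CCC(C)n1ncn(-c2ccc(N3CCN(c4ccc(OC[C@@H]5COC(c6ccc(Cl)cc6Cl)O5)cc4)CC3)cc2)c1=O`: 328 nM
Compound 2 `CCC(C)n1ncn(-c2ccc(N3CCN(c4ccc(OC[C@@H]5CO[C@@](Cc6ccccc6)(c6ccc(Cl)cc6Cl)O5)cc4)CC3)cc2)c1=O`: 513 nM
Compound 3 `CCC(C)n1ncn(-c2ccc(N3CCN(c4ccc(OC[C@@H]5CO[C@@](CN(C)C)(c6ccc(Cl)cc6Cl)O5)cc4)CC3)cc2)c1=O`: 1400 nM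

Compound 3 has the highest number of this small set, so it inhibits least in this assay. Compound 4 `CCC(C)n1ncn(-c2ccc(N3CCN(c4ccc(OC[C@@H]5CO[C@@](Cn6cnc(C)n6)(c6ccc(Cl)cc6Cl)O5)cc4)CC3)cc2)c1=O` changes one group of compound 3: 3-methyl-1H-1,2,4-triazol-1-yl in place of dimethylamino on a saturated chain carbon bound to a saturated ring carbon. Here 3-methyl-1H-1,2,4-triazol-1-yl takes the place of dimethylamino on a saturated chain carbon bound to a saturated ring carbon.

Among the measured compounds shown here, only one measured step bears on this place: a 2.7-fold higher number from compound 2 to compound 3 (0.44 log units; beyond the scatter), with dimethylamino replacing phenyl. That step is modest, and a single step is thin evidence. The incoming group brings an aromatic ring, as the phenyl of compound 2 at 513 nM does, so a return towards that lower number seems plausible, though it is not assured. A modest drop is therefore expected, estimated as a 2.2-fold lower number from compound 3 to compound 4 (0.33 log units; beyond the scatter). For compound 4 the expected value is 650 nM, with an estimated range from 220 nM to 1800 nM.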

Compound 4, half-maximal inhibitory concentration: 272 nM
Beside the measured number, compound 4's estimate is 2.4-fold (0.38 log units) above it; the range from low to high includes it.
By their numbers in this assay, from the lowest: compounds 4, 1 and 2 (each within the scatter of the next); then compound 3.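

In this assay, the group on this saturated chain carbon clearly affects the result: 3-methyl-1H-1,2,4-triazol-1-yl in place of dimethylamino gives a 5.1-fold lower number from compound 3 to compound 4 (0.71 log units; beyond the scatter), a step beyond the usual scatter. Replacing the phenyl with the same triazole gives a 1.9-fold lower number from compound 2 to compound 4 (0.28 log units; within the scatter), which lies within the scatter, so these two aromatic groups cannot be ranked here, and among the three groups at this place, only the non-aromatic dimethylamino stands apart from both. Nothing shown here explains these differences.

As far as these compounds go, it remains open how the triazole without its methyl group, or an imidazol-1-yl, would compare at this place. It is also unclear whether a cyclic amine such as morpholine would track dimethylamino or the two aromatic groups.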